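The source may hold more compounds than are shown below. What is called first, only, known or untested is meant among the compounds shown, and "the series" means these compounds.

Working notes on the series. In a functional assay on MDA-MB-231 cells (Homo sapiens) for inhibition, read by MTT assay, with a stated time of 48 h (a higher number here means a weaker inhibitor, a lower number a stronger inhibitor), compound 1 `C[Se]c1ccc(N(C)c2nc(C3CC3)nc3ccccc23)cc1` gives 18 nM and compound 3 `Cc1nc(N(C)c2ccc([Se]C#N)c(C)c2)c2ccccc2n1` gives 16 nM, two values within the scatter of each other. Compound 2 `COc1ccc(N(C)c2nc(C)nc3ccccc23)cc1C(=O)OCC[Se]C#N` stands apart at 1480 nM, the highest of the three numbers and beyond the scatter from both others, which makes it the weakest inhibitor measured so far.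

Compound 4 `COc1ccc(N(C)c2nc(C)nc3ccccc23)cc1C(=O)OCCC[Se]C#N` departs from compound 2 by a group of 4 heavy atoms (2 carbon, 1 nitrogen, 1 selenium; no ring) in place of a group of 3 heavy atoms (1 carbon, 1 nitrogen, 1 selenium; no ring), on a saturated chain carbon, two bonds along the chain from an oxygen next to a carbonyl group, on a saturated chain carbon, two bonds along the chain from an oxygen next to a carbonyl group. Within the data shown here, no measured pair isolates a change of this kind, so the expectation rests on compound 2 alone. The rest of the structure is unchanged, so the number is expected to stay close to that of compound 2 at 1480 nM, with no shift in either direction beyond the scatter.

The expected move is a 1.2-fold lower number from compound 2 to compound 4 (0.09 log units; within the scatter). For compound 4 the estimated value is 1200 nM, with an expected range from 450 nM to 3200 nM.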

Compound 4, half-maximal inhibitory concentration: 1180 nM
Estimate against measurement, compound 4: 1.0-fold (0.01 log units) above; measured number inside the range.
By their numbers in this assay, from the lowest: compounds 3 and 1 (each within the scatter of the next); then compounds 4 and 2 (each within the scatter of the next).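

In this assay, the change on this saturated chain carbon, two bonds along the chain from an oxygen next to a carbonyl group, gives a 1.3-fold lower number from compound 2 to compound 4 (0.10 log units; within the scatter), within the scatter. Among these compounds, this is the first pair that differs in one place, and at this position the group of 4 heavy atoms (2 carbon, 1 nitrogen, 1 selenium; no ring) and the group of 3 heavy atoms (1 carbon, 1 nitrogen, 1 selenium; no ring) cannot be told apart by their numbers. No measurement at hand bears on this result.

Going by these compounds, whether a longer chain carrying the same end group, or an amine or a carboxylic acid at this place, would read the same stays open. This step also says nothing about compound 1 or compound 3, which differ from this pair in more than one place.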